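A 3-methylphenyl variant of compound 1 on a shared core

This account rests on a few compounds, and the source may have more. Where it says the series, first, only, none or still open, it means among the compounds named here.

Compound 1 `O=C(/C=C/c1ccc2c(c1)B(O)OC2)c1ccc(Cl)cc1` is tested in a functional assay on MDA-MB-231 cells (Homo sapiens) for cytotoxicity, read by MTT assay, with a stated time of 48 h (on this read-out higher numbers stand for weaker inhibition and lower numbers for stronger inhibition), and gives 7900 nM. Among the three measured compounds, compound 1 holds the second highest number. Compound 2 `O=C(/C=C/c1ccc2c(c1)B(O)OC2)c1ccc(OCc2ccccc2)cc1` gives 5300 nM in this assay, and compound 3 `CCOC(=O)c1ccc(C(=O)/C=C/c2ccc3c(c2)B(O)OC3)cc1` gives 13000 nM. Benzyloxy in place of chloro gives a 1.5-fold lower number from compound 1 to compound 2 (0.17 log units; within the scatter), ethoxycarbonyl in place of chloro gives a 1.6-fold higher number from compound 1 to compound 3 (0.22 log units; within the scatter), and ethoxycarbonyl in place of benzyloxy gives a 2.5-fold higher number from compound 2 to compound 3 (0.39 log units; beyond the scatter). All three measured changes to the aryl group attached to the carbonyl carbon thus moved the number only slightly, with one of them reaching a modest size.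

Compound 4 `Cc1cccc(C(=O)/C=C/c2ccc3c(c2)B(O)OC3)c1` differs from compound 1 by 3-methylphenyl in place of 4-chlorophenyl on a carbonyl carbon. Among the measured compounds shown here, no measured step places a methyl on that aryl ring, so the expectation rests on the small shifts seen for the other aryl swaps. Compound 4 is therefore expected to give about 8000 nM in this assay, with a range of 3500 nM to 18000 nM. This estimate amounts to a 1.0-fold higher number from compound 1 to compound 4 (0.01 log units; within the scatter), a step expected to stay within the scatter.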

Compound 4, half-maximal inhibitory concentration: 4500 nM
Estimate against measurement, compound 4: 1.8-fold (0.25 log units) above; the range from low to high includes it.
By their numbers in this assay, from the lowest: compounds 4, 2, 1 and 3 (each within the scatter of the next, the first and the last beyond it).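

In this assay, 3-methylphenyl in place of 4-chlorophenyl on a carbonyl carbon gives a 1.8-fold lower number from compound 1 to compound 4 (0.24 log units; within the scatter), so this aryl position tolerates this swap without a shift beyond the scatter. Among the compounds shown, only compound 4 has an aryl group made of carbon alone, which shows that neither chlorine nor the oxygen-bearing groups of compound 2 and compound 3 are needed for a number in this range. Nothing available here explains the size of this step.

Whether 4-methylphenyl or 3-chlorophenyl would match compound 4 remains open, so the compounds shown do not separate the change of substituent from the change of its place on the ring. Also open, going by these compounds, is whether an amine or a carboxylic acid on this aryl ring would move the number beyond the scatter.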